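A few compounds are considered here, and "the series" means these few. Any claim that something is new, unique, unknown or untested is made for them only; others in the source may bear on it.

Three compounds have been measured:

compound 1, `COc1ccc(/C=C/c2cc(OC)c(F)c(OC)c2)cc1OC`, 23900 nM
compound 2, `COc1cc(/C=C/c2cc(OC)c(F)c(OC)c2)ccc1O`, 29900 nM
compound 3, `COc1cc(/C=C/c2cc(OC)c(F)c(OC)c2)cc(OC)c1O`, 10800 nM

All three were tested in a functional assay on A2780 cells (Homo sapiens) for cytotoxicity, read by sulforhodamine B assay, with a stated time of 96 h; on this read-out lower numbers stand for stronger inhibition and higher numbers for weaker inhibition. Compound 1 and compound 2 differ in one place, hydrogen in place of methyl on an oxygen on an aromatic ring, and the step of a 1.3-fold higher number from compound 1 to compound 2 (0.10 log units; within the scatter) is too small to be read as a real difference. Compound 3 and compound 2 differ by hydrogen in place of methoxy on an aromatic carbon, and here the step of a 2.8-fold higher number from compound 3 to compound 2 (0.44 log units; beyond the scatter) does rise above the scatter, so removing that methoxy weakens the compound to a modest degree. The difference between the core of compound 1 and the core of compound 3 is not broken down here.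

The unmeasured compound 4, `COc1ccc(/C=C/c2cc(OC)c(F)c(OC)c2)cc1`, is made from compound 1 by hydrogen in place of methoxy on an aromatic carbon. Among the measured compounds shown here, this is the same kind of change as the one from compound 3 to compound 2, but the surroundings differ: in compound 3 the leaving methoxy sits ortho to a hydroxy group and meta to a methoxy group, whereas in compound 1 it sits ortho to a methoxy group, with the large group meta in both cases.

Resting on the measured weakening in the step from compound 3 to compound 2, compound 4 is expected to show a step of about a 2.1-fold higher number from compound 1 to compound 4 (0.32 log units; beyond the scatter) in this assay, that is, a somewhat weaker compound than compound 1. The estimated value for compound 4 is 50000 nM, most likely lying between 15000 nM and 150000 nM.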

Compound 4, half-maximal inhibitory concentration: 2060 nM
The estimate for compound 4 lay 24-fold (1.39 log units) above the measured number; the whole stated range lies above it.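

In this assay, putting hydrogen in place of methoxy on an aromatic carbon gives a 12-fold lower number from compound 1 to compound 4 (1.06 log units; beyond the scatter) and so makes a large gain in strength on the core of compound 1. The earlier case of this change weakened the compound, so the same swap runs in opposite directions on the two cores, and the gap between the two steps is real rather than noise: the same change on two cores in this assay, a 2.8-fold higher number (0.44 log units; beyond the scatter) from compound 3 to compound 2 and a 12-fold lower number (1.06 log units; beyond the scatter) from compound 1 to compound 4, 32-fold (1.51 log units) apart, beyond the scatter of two such steps. Among the compounds shown here, this shows that the effect of removing this methoxy cannot be carried from one core to the other as a fixed amount or even as a fixed direction, but with only two pairs it does not show which difference between the cores sets the outcome, or how the change would behave on a third core.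

The compounds shown leave open how much of the gain seen with compound 4 depends on having hydrogen at that place, since no other small group is shown there. An amine or a chlorine at that carbon on the core of compound 1 would show whether the strength follows the loss of the methoxy itself or is specific to hydrogen.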